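A few compounds are considered here, and "the series" means these few. Any claim that something is new, unique, unknown or untested is made for them only; others in the source may bear on it.

In a functional assay on HEK293 cells for agonist activity at nuclear receptor subfamily 1 group D member 1 (Homo sapiens), read by a luciferase reporter, with a stated time of 24 h (on this read-out lower numbers stand for an effect already at smaller amounts and higher numbers for an effect only at larger amounts of compound), compound 2 `Cc1ccc(S(=O)(=O)N(CC(=O)OC(C)(C)C)Cc2ccc([N+](=O)[O-])s2)cc1` gives 3000 nM, and compound 3 `NC(=O)CN(Cc1ccc(Cl)cc1)Cc1ccc([N+](=O)[O-])s1` gives 3000 nM. These two values lie within the scatter of each other, so compound 3 stands level with compound 2 on the numbers shown. In this assay compound 1 `CC(C)(C)OC(=O)CN(Cc1ccccc1)Cc1ccc([N+](=O)[O-])s1` gives "not determined" (no result reported), so no result is available for it. Compound 4 `O=[N+]([O-])c1ccc(CN(Cc2ccc(Cl)cc2)CC2CCCCC2)s1` differs from compound 3 in one place: cyclohexyl in place of carbamoyl on a saturated chain carbon bound to an amine nitrogen. For the measured compounds named here, no measured pair shows this same change, so its effect in this assay is not known from the data, and the two measured values give no hint of direction. A modest step toward lower numbers, or none beyond the scatter, is expected. Compound 4 is estimated at 1500 nM, within a range from 400 nM to 8000 nM. The expected step is a 2.0-fold lower number from compound 3 to compound 4 (0.30 log units; within the scatter).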

Compound 4, half-maximal effective concentration: 7400 nM
Compound 4: the middle estimate sits 4.9-fold (0.69 log units) below what was measured, and the stated range covers the measured number.
By their numbers in this assay, from the lowest: compounds 2 and 3 (each within the scatter of the next); then compound 4.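

In this assay, cyclohexyl in place of carbamoyl on a saturated chain carbon bound to an amine nitrogen gives a 2.5-fold higher number from compound 3 to compound 4 (0.39 log units; beyond the scatter), a modest step that lies beyond the scatter. This position therefore accepts a ring of carbon only and still gives a measured value, but carbamoyl gives the lower number of the two. Nothing available explains this step.

From the compounds shown here alone, the change removes the hydrogen-bond donor and acceptor of carbamoyl and adds a ring in one move, so their separate effects remain open. A carboxylic acid or a short alkyl chain in this place could help to tell them apart.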